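The source may report more compounds than this note shows. Statements on the series, on what has been measured and on what is new or still open speak of the compounds shown alone.

Working notes, series of the shared core as in compound 2 `COc1ccc(COCC(Cn2ccnc2)OCc2ccc(C(=O)Oc3ccccc3)cc2)cc1`. In a functional assay for inhibition of Thromboxane-A synthase (Homo sapiens) (on this read-out higher numbers stand for weaker inhibition and lower numbers for stronger inhibition), compound 2 gives 560 nM, the lowest of the three numbers seen so far. Compound 1 `COc1ccc(COCC(Cn2ccnc2)OCc2ccc(OC)cc2)cc1` gives 9900 nM and compound 3 `CCCCCCCCOC(=O)c1ccc(COC(COCc2ccc(OC)cc2)Cn2ccnc2)cc1` gives 21000 nM. The step of an 18-fold lower number from compound 1 to compound 2 (1.25 log units; beyond the scatter) and the step of a 38-fold higher number from compound 2 to compound 3 (1.57 log units; beyond the scatter) are both large; the step of a 2.1-fold higher number from compound 1 to compound 3 (0.33 log units; beyond the scatter) is modest.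

Compound 4 `COc1ccc(COCC(Cn2ccnc2)OCc2ccc(S(C)(=O)=O)cc2)cc1` differs from compound 2 by methylsulfonyl in place of phenoxycarbonyl on an aromatic carbon. The two large steps both involve the phenoxycarbonyl group: putting it in place of methoxy lowered the number sharply, and swapping its phenyl for octyl raised it even more sharply. Removing the phenoxycarbonyl altogether in favour of methylsulfonyl is therefore expected to give a large step upward, an 11-fold higher number from compound 2 to compound 4 (1.03 log units; beyond the scatter), in this assay. The estimate for compound 4 is 6000 nM, with a range from 1500 nM to 25000 nM.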

Compound 4, half-maximal inhibitory concentration: 24900 nM
For compound 4 the middle estimate is 4.2-fold (0.62 log units) below the measured one; the measured number falls inside the stated range.
By their numbers in this assay, from the lowest: compound 2; then compound 1; then compounds 3 and 4 (each within the scatter of the next).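

In this assay, methylsulfonyl on this aromatic carbon gives up what phenoxycarbonyl gained (a 44-fold higher number from compound 2 to compound 4 (1.65 log units; beyond the scatter)) and also stands apart from methoxy (a 2.5-fold higher number from compound 1 to compound 4 (0.40 log units; beyond the scatter)), so among the four groups only phenoxycarbonyl gives a low number. Methylsulfonyl and octyloxycarbonyl cannot be told apart (a 1.2-fold higher number from compound 3 to compound 4 (0.07 log units; within the scatter)), although only the latter keeps a carbonyl, so a carbonyl at this place is not enough for a low number. No measurement at hand accounts for the standing of phenoxycarbonyl. Open, on these data alone, is whether the low number depends on the aromatic ring of phenoxycarbonyl, which a benzyloxycarbonyl group, a cyclohexyloxycarbonyl group or a carboxylic acid at this carbon would test.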